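The source may hold more compounds than are shown below. What is called first, only, known or untested is meant among the compounds shown, and "the series" means these compounds.

The compounds measured in a functional assay on KG-1 cells (Homo sapiens) for antiproliferative activity; a higher number here means that more compound is needed for the effect, a lower number that less compound is needed:
compound 1, `CC1(C#Cc2c(Cl)c3c(Cl)cc(C(N)=O)nc3n2[C@H]2CCCNC2)COC1`, gives 119 nM
compound 2, `CC1(CC#Cc2c(Cl)c3c(Cl)cc(C(N)=O)nc3n2[C@H]2CCCNC2)COC1`, gives 289 nM
compound 3, `NC(=O)c1cc(Cl)c2c(Cl)c(C#CC3COCCO3)n([C@H]3CCCNC3)c2n1`, gives 77 nM; 203 nM (2 entries)

Of the two compounds with a single number, compound 1 stands lowest, and its nearest neighbour is compound 2, reached by a 2.4-fold higher number from compound 1 to compound 2 (0.39 log units; beyond the scatter). Compound 3 is recorded as the several entries of compound 3 in this assay, 77 nM; 203 nM (2 entries), which gives no single number to set against compound 1. Among the measured compounds shown here, the one step with a value is thus the one from compound 1 to compound 2, a modest move to a higher number that lies beyond the scatter.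

Compound 4, `CC(O)CC#Cc1c(Cl)c2c(Cl)cc(C(N)=O)nc2n1[C@H]1CCCNC1`, differs from compound 1 in one place: 2-hydroxypropyl in place of 3-methyloxetan-3-yl on a triple-bonded carbon. The step that bears on it is a 2.4-fold higher number from compound 1 to compound 2 (0.39 log units; beyond the scatter), in which the group on the triple-bonded carbon was also altered while the rest of the shared core stayed the same. A change of similar size and direction is expected here, with the ring gone and a hydrogen-bond donor present as the counted difference shows. The step from compound 1 to compound 4 is therefore expected to be a 1.8-fold higher number from compound 1 to compound 4 (0.27 log units; within the scatter). For compound 4 the estimate in this assay is 220 nM, with a range from 100 nM to 480 nM.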

Compound 4, half-maximal effective concentration: 48 nM
Compound 4: the middle estimate sits 4.6-fold (0.66 log units) above what was measured; measured number below the stated range.
By their numbers in this assay, from the lowest: compound 4; then compound 1; then compound 2.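

In this assay the group on the triple-bonded carbon can lower the number as well as raise it: the earlier step was upward, a 2.4-fold higher number from compound 1 to compound 2 (0.39 log units; beyond the scatter), while 2-hydroxypropyl in place of 3-methyloxetan-3-yl gives a 2.5-fold lower number from compound 1 to compound 4 (0.39 log units; beyond the scatter) and so reverses the direction. Set against the longer oxetane-bearing chain, the same compound shows a larger step, a 6.0-fold lower number from compound 2 to compound 4 (0.78 log units; beyond the scatter), with 1-hydroxyethyl in place of 3-methyloxetan-3-yl on a saturated chain carbon bound to a triple-bonded carbon. Among the compounds with a single number, compound 4 therefore has the lowest value, and it reaches this with no ring in the group at this place, so the four-membered ring is not required for a low number here.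

The change removes the ring and adds a hydrogen-bond donor in one move, so the two cannot be separated, and nothing measured here accounts for the direction of the step. The compounds shown also leave open how an amine or a methoxy group in place of the hydroxyl on this chain, or a longer chain carrying the hydroxyl, would read in this assay on the same core.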